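Phenyl for Trifluoromethyl on a Sulfonyl Sulfur: Two Cores

The source may hold more compounds than are shown below. What is called first, only, known or untested is meant among the compounds shown, and "the series" means these compounds.

Of the compounds shown here, three of this set have been measured in a physicochemical assay for lipophilicity; a higher number here means a more lipophilic compound, a lower number a more polar compound. Compound 1 `CCCN(CCn1cc[n+](C)c1/C=N/O)S(=O)(=O)C(F)(F)F` gives -0.69 in this assay. Compound 3 `CCCN(CCn1cc[n+](C)c1/C=N/O)S(=O)(=O)c1ccccc1` gives -0.94 in this assay. Compound 2 `C[n+]1ccn(CCCNS(=O)(=O)C(F)(F)F)c1/C=N/O` gives -1.26 in this assay, the lowest of the three numbers; its nearest neighbour is compound 3, and compound 1 stands furthest from it, both gaps beyond the usual scatter of repeated measurements. The difference between the core of compound 1 and the core of compound 2 is not broken down here.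

Compound 3 arises from compound 1 by one change: phenyl in place of trifluoromethyl on a sulfonyl sulfur. That change gave a number 0.25 log units lower from compound 1 to compound 3 (within the scatter), a step that lies within the scatter of this kind of measurement.

Compound 4 `C[n+]1ccn(CCCNS(=O)(=O)c2ccccc2)c1/C=N/O` has not yet been measured in this assay. It arises from compound 2 by the same change: phenyl in place of trifluoromethyl on a sulfonyl sulfur. Since this change left the value essentially unmoved between compound 1 and compound 3, as a number 0.25 log units lower from compound 1 to compound 3 (within the scatter) shows, a small downward step of similar size is expected on the core of compound 2 as well. The expected step from compound 2 to compound 4 is a number 0.25 log units lower from compound 2 to compound 4 (within the scatter). Starting from compound 2 with its -1.26, compound 4 is therefore estimated at -1.51 in this assay. The estimate for compound 4 is expected to fall between -1.95 and -1.1. The measurement of compound 4 will show whether this expectation holds.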

Compound 4, distribution coefficient: -1.89
Compound 4: the middle estimate sits 0.38 log units above what was measured; the range from low to high includes it.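

In this assay, the change from trifluoromethyl to phenyl on a sulfonyl sulfur gave a number 0.63 log units lower from compound 2 to compound 4 (beyond the scatter), a step beyond the scatter, whereas on the core of compound 1 the same change gave a number 0.25 log units lower from compound 1 to compound 3 (within the scatter), a step that cannot be told from repeat variation. Going by these compounds alone, this shows that the change can register clearly on the core of compound 2 even though it did not do so on the core of compound 1, so a step read on one core did not settle the size of the step on the other; it does not show that the two cores truly respond differently, since each core offers only a single pair and a single comparison. Nothing available explains the result on the core of compound 2, and no reason for it can be offered from these data.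

The compounds shown leave open how other groups on the sulfonyl sulfur, such as methyl, an amine or a carboxylic acid-bearing chain, would behave on either core. They also leave open whether a longer chain on the sulfonamide nitrogen would alter the step seen for this change.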